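Swapping the pyrazole for a triazole in an H2 agonist series

A few compounds are considered here, and "the series" means these few. Any claim that something is new, unique, unknown or untested is made for them only; others in the source may bear on it.

Going by the values given here, compound 2 `CC(CC(=O)/N=C(\N)NCCCc1cn[nH]c1)c1ccccc1` stands lowest of the two numbers so far: in an assay on Sf9 cells for agonist activity at histamine H2 receptor (Homo sapiens), with stated times of 2 min and 20 min (on this read-out lower numbers stand for an effect already at smaller amounts and higher numbers for an effect only at larger amounts of compound), compound 2 gives 240 nM, while compound 1 `CC(CC(=O)/N=C(\N)NCCCc1ccccn1)c1ccccc1` gives 832 nM. Among the compounds with values here, the one measured step, a 3.5-fold lower number from compound 1 to compound 2 (0.54 log units; beyond the scatter), shows that the ring at the chain end matters. Compound 3 `CC(CC(=O)/N=C(\N)NCCCc1ncn[nH]1)c1ccccc1` carries the change (1H-1,2,4-triazol-5-yl in place of 1H-pyrazol-4-yl on a saturated chain carbon, three bonds along the chain from an amine nitrogen). Within the data shown here, no measured pair shows this exact exchange, so the direction is uncertain; a small rise beyond the scatter is expected, a 1.9-fold higher number from compound 2 to compound 3 (0.27 log units; within the scatter). Compound 3 is therefore estimated at 450 nM, within a range of 120 nM to 1700 nM.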

Compound 3, half-maximal effective concentration: 741 nM
Compound 3: the middle estimate sits 1.6-fold (0.22 log units) below what was measured; the measured number falls inside the stated range.
By their numbers in this assay, from the lowest: compound 2; then compounds 3 and 1 (each within the scatter of the next).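

In this assay, the ring at this place, on a saturated chain carbon, three bonds along the chain from an amine nitrogen, responds even to a change between two five-membered aromatic rings: 1H-1,2,4-triazol-5-yl in place of 1H-pyrazol-4-yl gives a 3.1-fold higher number from compound 2 to compound 3 (0.49 log units; beyond the scatter). The six-membered pyridin-2-yl ring and the triazole show no real separation, with a 1.1-fold lower number from compound 1 to compound 3 (0.05 log units; within the scatter), so of these three rings only the pyrazole stands apart. Nothing available explains this difference. Still open, going by these compounds, is whether a longer chain carrying the 1H-pyrazol-4-yl group would lower the number further than compound 2 does.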